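The source may hold more compounds than are shown below. What is called first, only, known or untested is meant among the compounds shown, and "the series" means these compounds.

In a functional assay on HCT-116 cells (Homo sapiens) for antiproliferative activity, read by MTT assay (a lower number here means a stronger inhibitor, a higher number a weaker inhibitor), three compounds that share one core and differ only in the group hanging from the carbon with a double bond to nitrogen have been tested. Compound 1 `Cn1c(=O)c(=O)n(C2CCCC2)c2nc(N/N=C/c3ccccc3)ncc21` reaches only the limit of the assay, > 100000 nM, and no number is read. Compound 2 `Cc1cccc(/C=N/Nc2ncc3c(n2)n(C2CCCC2)c(=O)c(=O)n3C)c1` likewise stops at the limit, > 100000 nM. Within the data shown here, compound 3 `Cn1c(=O)c(=O)n(C2CCCC2)c2nc(N/N=C/c3cccs3)ncc21` is the one member of the set that gives a number in this assay, 52600 nM, so it stands apart from the other two, both of which sit at the limit of > 100000 nM in this assay, at which 2 of the 3 values shown sit. Because of that limit the step that the two limits leave unreadable from compound 1 to compound 2 cannot be read. The steps of an at least 1.9-fold lower number from compound 1 to compound 3 (0.27 log units; that floor lies within the scatter) and an at least 1.9-fold lower number from compound 2 to compound 3 (0.27 log units; that floor lies within the scatter) are floors only, and each floor lies within the scatter.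

Compound 4 `COc1ccc(/C=N/Nc2ncc3c(n2)n(C2CCCC2)c(=O)c(=O)n3C)c(OC)c1` is the next step from compound 3: 2,4-dimethoxyphenyl in place of thiophen-2-yl on a carbon with a double bond to nitrogen. Among the measured compounds shown here, this change returns to a six-membered ring of carbon only, the kind of ring carried by compound 1 and compound 2, both of which gave only the limit, while the thiophen-2-yl of compound 3 gave the sole number. The expected step of a 1.7-fold higher number from compound 3 to compound 4 (0.23 log units; within the scatter) is therefore upward, toward a weaker inhibitor, and the number may again fall past the limit. Compound 4 is estimated at 90000 nM, within a range from 30000 nM to 300000 nM.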

Compound 4, half-maximal inhibitory concentration: > 100000 nM
Compound 4: no number, only a limit; the forecaster's own chance of this, stated with the estimate: 55%; at least 1.1-fold (0.04 log units) between middle value and limit.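

In this assay, the 2,4-dimethoxyphenyl group of compound 4 adds two oxygen-bearing substituents to the six-membered ring of carbon only, yet this compound too gives only a limit and no number. All three compounds with such a ring at this place, compound 1, compound 2 and compound 4, now end at that limit, and only the thiophen-2-yl of compound 3 gives a number. The change reads as an at least 1.9-fold higher number from compound 3 to compound 4 (0.27 log units; that floor lies within the scatter), so its true size remains unknown, the steps from compound 1 and from compound 2 to compound 4 cannot be read, and one limit now dominates the set: the limit of > 100000 nM in this assay, at which 3 of the 4 values shown sit.

On these data alone, with a single number in the set, it remains open whether the five-membered ring, its sulfur or some other feature of the thiophen-2-yl group separates compound 3 from the others. The compounds shown also leave open how a furan-2-yl group, or a phenyl ring carrying an amine or a carboxylic acid, would behave on this carbon with a double bond to nitrogen.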